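From cyclohexyl to piperazin-1-yl: a small step expected

A few compounds are considered here, and "the series" means these few. Any claim that something is new, unique, unknown or untested is made for them only; others in the source may bear on it.

Compound 1 `O=C(/C=C/c1ccc([N+](=O)[O-])o1)c1ccc(Br)cc1`: 85400 nM
Compound 2 `O=C(/C=C/c1ccc([N+](=O)[O-])o1)c1ccc(I)cc1`: 68200 nM
Compound 3 `O=C(/C=C/c1ccc([N+](=O)[O-])o1)c1ccc(C2CCCCC2)cc1`: 57200 nM

These numbers come from an ADME assay on cells (Astrocyte, Rattus norvegicus, strain Wistar) for inhibition, read by sulforhodamine B assay, with a stated time of 72 h; a lower number here means that less compound is tolerated, a higher number that more compound is tolerated. Compound 3 cannot be told apart from the other two: the data show a 1.5-fold lower number from compound 1 to compound 3 (0.17 log units; within the scatter) and a 1.2-fold lower number from compound 2 to compound 3 (0.08 log units; within the scatter). The unmeasured compound 4 `O=C(/C=C/c1ccc([N+](=O)[O-])o1)c1ccc(N2CCNCC2)cc1` carries piperazin-1-yl in place of cyclohexyl on an aromatic carbon, and the count of what changes is piperazin-1-yl in place of cyclohexyl on an aromatic carbon. The same place was changed in the measured steps, and a 1.3-fold lower number from compound 1 to compound 2 (0.10 log units; within the scatter) was also small. None of these steps brought in a ring with hetero atoms, so the range is kept wide. No step beyond the scatter is expected, and the estimate is a 1.0-fold higher number from compound 3 to compound 4 (0.02 log units; within the scatter). For compound 4 the estimated value is 60000 nM, with an expected range from 25000 nM to 130000 nM.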

Compound 4, half-maximal cytotoxic concentration: 44300 nM
The estimate for compound 4 lay 1.4-fold (0.13 log units) above the measured number; measured number inside the range.
By their numbers in this assay, from the lowest: compounds 4, 3, 2 and 1 (each within the scatter of the next).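

In this assay, within the data shown here, the piperazin-1-yl ring brings hetero atoms, a hydrogen-bond donor and hydrogen-bond acceptors to this position for the first time, yet a 1.3-fold lower number from compound 3 to compound 4 (0.11 log units; within the scatter) is a step that stays small. Set against iodo and bromo the picture is the same, with a 1.5-fold lower number from compound 2 to compound 4 (0.19 log units; within the scatter) and a 1.9-fold lower number from compound 1 to compound 4 (0.29 log units; within the scatter) as the other two steps. No measurement shown accounts for this result.

On these data alone, whether a carboxylic acid or a longer chain at this position would give a step beyond the scatter stays open. So does whether a change elsewhere on the shared core would matter more.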